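A few compounds are considered here, and "the series" means these few. Any claim that something is new, unique, unknown or untested is made for them only; others in the source may bear on it.

Among the measured compounds shown here, compound 3, `CC/C=C\C[C@H]1C(=O)C=C[C@H]1CC(=O)OCCOCCO`, stands at the top of the numbers so far in an ADME assay on RAW264.7 cells (Mus musculus) for cytotoxicity, read by MTT assay, with a stated time of 24 h; on this read-out higher numbers stand for lower toxicity in this test and lower numbers for higher toxicity in this test: compound 3 gives 166 uM. Compound 1, `CC/C=C\C[C@H]1C(=O)C=C[C@H]1CC(=O)OCC`, sits close by; in this assay compound 1 gives 146 uM, and the pair differ only as a 1.1-fold higher number from compound 1 to compound 3 (0.06 log units; within the scatter). Compound 2, `CC/C=C\C[C@H]1C(=O)C=C[C@H]1CC(=O)OCc1ccccc1`, is the outlier; in this assay compound 2 gives 31 uM, the step being a 4.7-fold lower number from compound 1 to compound 2 (0.67 log units; beyond the scatter), and in the other direction a 5.4-fold higher number from compound 2 to compound 3 (0.73 log units; beyond the scatter).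

Compound 4, `CC/C=C\C[C@H]1C(=O)C=C[C@H]1CC(=O)OC(C)COC`, is the next ester in the series. The change from compound 3 is 1-(methoxymethyl)ethyl in place of 2-(2-hydroxyethoxy)ethyl on an oxygen next to a carbonyl group. Among the measured steps, the one from compound 1 to compound 3 is the closest analogy, since it too alters the ester alcohol without bringing in a ring, and it stayed within the scatter. The two steps that did move beyond the scatter, those involving compound 2, both carry a phenyl, which is absent from compound 4. For the measured compounds named here, no measured step covers the loss of the hydroxyl or the branching at the oxygen next to the carbonyl. Compound 4 is therefore expected to land near compound 3 and compound 1, with the step from compound 3 estimated as a 1.3-fold lower number from compound 3 to compound 4 (0.11 log units; within the scatter), and the value for compound 4 expected at 130 uM, within 60 uM to 260 uM.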

Compound 4, half-maximal toxic concentration: 161 uM
Compound 4: the middle estimate sits 1.2-fold (0.09 log units) below what was measured, within the range that was stated.
By their numbers in this assay, from the lowest: compound 2; then compounds 1, 4 and 3 (each within the scatter of the next).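

In this assay, 1-(methoxymethyl)ethyl in place of 2-(2-hydroxyethoxy)ethyl on an oxygen next to a carbonyl group gives a 1.0-fold lower number from compound 3 to compound 4 (0.01 log units; within the scatter) and stays level, so this position tolerates together the loss of the hydroxyl, the shorter chain and branching at the carbon bound to that oxygen. Methoxymethyl in place of hydrogen on that carbon likewise leaves the number unmoved, with a 1.1-fold higher number from compound 1 to compound 4 (0.04 log units; within the scatter) as the step, whereas the change from benzyl reads as a 5.2-fold higher number from compound 2 to compound 4 (0.72 log units; beyond the scatter) and keeps compound 2 apart from compounds 1, 3 and 4, which show no separation from one another. The data on hand offer no explanation for this flat behaviour among the three esters without a phenyl or for the separate place of compound 2.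

Open, as far as these compounds go, is whether the lower number of compound 2 goes with the phenyl of benzyl specifically or would also appear with a saturated cyclohexylmethyl ester or a longer chain such as octyl. Also open, from the compounds shown here alone, is how an ester carrying an amine, such as 2-(dimethylamino)ethyl, or the free carboxylic acid on the shared core would read in this assay.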